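Alpha-ketoheterocycle series: fused ring removed from compound 3

A few compounds are considered here, and "the series" means these few. Any claim that something is new, unique, unknown or untested is made for them only; others in the source may bear on it.

Measured so far in an assay on isolated protein for inhibition of Fatty-acid amide hydrolase 1 (Homo sapiens); on this read-out higher numbers stand for weaker inhibition and lower numbers for stronger inhibition:
compound 1, `CCCCCCCC/C=C\CCCCCCC(=O)c1ncc(-c2ccoc2)o1`, 610 nM
compound 2, `CCCCCCCC/C=C\CCCCCCC(=O)c1nc2ncccc2o1`, 2.3 nM
compound 3, `CCCCCCCC/C=C\CCCCCCC(=O)c1nc2ccccc2o1`, 370 nM

Compound 3 stands second highest of the three; its value and that of compound 1 lie within the scatter of each other, while compound 2 sits far lower. Within the data shown here, the one measured step on the ring attached to the carbonyl, a 160-fold higher number from compound 2 to compound 3 (2.21 log units; beyond the scatter), was large. Compound 4, `CCCCCCCC/C=C\CCCCCCC(=O)c1ncco1`, carries 1,3-oxazol-2-yl in place of 1,3-benzoxazol-2-yl on a carbonyl carbon. Among the measured compounds shown here, no measured step shows this change; compound 1, which also has a five-membered ring alone at the carbonyl, gives a number close to compound 3. Expectation for compound 4 is therefore a moderate move upward in this assay, a 4.1-fold higher number from compound 3 to compound 4 (0.61 log units; beyond the scatter), with wide uncertainty. Estimated value for compound 4: 1500 nM, range 400 nM to 6000 nM.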

Compound 4, inhibition constant: 17 nM
Estimate against measurement, compound 4: 88-fold (1.95 log units) above; the whole stated range lies above it.
By their numbers in this assay, from the lowest: compound 2; then compound 4; then compounds 3 and 1 (each within the scatter of the next).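

In this assay the six-membered aromatic ring of carbon only carries a cost at this place on the carbonyl carbon, with a 22-fold lower number from compound 3 to compound 4 (1.34 log units; beyond the scatter). The smaller 1,3-oxazol-2-yl still falls short of the fused ring with a ring nitrogen, with a 7.4-fold higher number from compound 2 to compound 4 (0.87 log units; beyond the scatter), and hydrogen in place of furan-3-yl gives a 36-fold lower number from compound 1 to compound 4 (1.55 log units; beyond the scatter). No measured evidence on why these steps arise is available.

Still open, as far as these compounds go, is how a carboxylic acid or a methyl on the 1,3-oxazol-2-yl ring would read here. Also open, from the compounds shown here alone, is whether a shorter saturated chain would keep these steps.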